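The source may hold more compounds than are shown below. What is called first, only, known or untested is meant among the compounds shown, and "the series" means these compounds.

Measured compounds, read in a functional assay on U-373MG ATCC cells (Homo sapiens) for cytotoxicity, read by MTT assay, with a stated time of 72 h; on this read-out lower numbers stand for stronger inhibition and higher numbers for weaker inhibition:
compound 1 `COc1ccc2[nH]c(-c3ccc[nH]3)c(C3CC(=O)NC3=O)c2c1`, 15000 nM
compound 3 `Cc1ccc2[nH]c(-c3ccc[nH]3)c(C3CC(=O)NC3=O)c2c1`, 5000 nM
compound 2 `COc1ccc2[nH]c(-n3cccn3)cc2c1`, a limit of the assay, > 100000 nM

Compound 1 and compound 3 share a core and differ in one place: methyl in place of methoxy on an aromatic carbon. This single change gives a 3.0-fold lower number from compound 1 to compound 3 (0.48 log units; beyond the scatter), a step beyond the scatter of repeated measurements.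

Compound 2 carries a different core; how the core of compound 2 differs from the core of compound 1 is not broken down here. In this assay compound 2 reaches only a limit, > 100000 nM, which is the limit of > 100000 nM in this assay, at which 1 of the 3 values shown sits. For the measured compounds named here, no number is known for compound 2, only that its value is past that limit.

Compound 4 `Cc1ccc2[nH]c(-n3cccn3)cc2c1` is not yet measured. It differs from compound 2 in one place: methyl in place of methoxy on an aromatic carbon. The place of this change is described word for word as in the pair compound 1 to compound 3, so it is the same change, here made on the core of compound 2. Going by the values given here, the only guide for its size is that the same change gave a 3.0-fold lower number from compound 1 to compound 3 (0.48 log units; beyond the scatter). The starting point for compound 4 is a limit rather than a number, and a step of that size may still leave compound 4 past the limit, so a limit is again the likelier outcome. The step expected from compound 2 to compound 4 is a number no higher from compound 2 to compound 4 (the limit leaves the size open). Compound 4 is expected to give 100000 nM, with a range estimated from 30000 nM to 300000 nM.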

Compound 4, half-maximal inhibitory concentration: > 100000 nM
Compound 4 was reported as a limit (the forecaster's own chance of this, stated with the estimate: 70%); the middle value lies on the limit itself.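

In this assay compound 4 gives > 100000 nM as a limit of the assay and not a number, so no step can be read between compound 2 and compound 4, which both stop at the same limit: the limit of > 100000 nM in this assay, at which 2 of the 4 values shown sit.

Going by these compounds, it stays open whether methyl in place of methoxy shifts the number on the core of compound 2 as it does on the core of compound 1.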